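Three Limits and a Cinnamate Ester Still to Be Read

The source may hold more compounds than are shown below. What is called first, only, known or untested is meant among the compounds shown, and "the series" means these compounds.

Compound 1 `COc1ccc(/C=C/C(=O)c2ccc(OC)c3c2OC(C)(C)C=C3)cc1O`: in an ADME assay on L02 cells (Homo sapiens) for cytotoxicity, read by MTT assay (on this read-out lower numbers stand for stronger inhibition and higher numbers for weaker inhibition), compound 1 gives > 10000 nM, which is a limit of the assay.
Compound 2 `COc1ccc(/C=C/C(=O)c2ccc(OC)c3c2OC(C)(C)C=C3)cc1OCCO`: in this assay compound 2 gives > 10000 nM, a limit of the assay.
Compound 3 `CCCCC(=O)Oc1cc(/C=C/C(=O)c2ccc(OC)c3c2OC(C)(C)C=C3)ccc1OC`: in this assay compound 3 gives > 10000 nM, again a limit of the assay.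

Compound 2 therefore stands at the limit of this assay, and the two other values shown are limits too (the limit of > 10000 nM in this assay, at which 3 of the 3 values shown sit). The three steps between the measured compounds, a step that the two limits leave unreadable from compound 1 to compound 2, a step that the two limits leave unreadable from compound 1 to compound 3 and a step that the two limits leave unreadable from compound 2 to compound 3, cannot be read in size or direction because of the limit of > 10000 nM in this assay, at which 3 of the 3 values shown sit.

Compound 4 `COc1ccc(/C=C/C(=O)Oc2cc(/C=C/C(=O)c3ccc(OC)c4c3OC(C)(C)C=C4)ccc2OC)cc1` differs from compound 2 in one place: (2-(4-methoxyphenyl)ethenyl)carbonyl in place of 2-hydroxyethyl on an oxygen on an aromatic ring.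

Every measured change on this oxygen, from hydrogen to 2-hydroxyethyl and to butylcarbonyl, left the value at the limit. Going by the values given here, no measured step shows a change that can be sized, so no step beyond the scatter is expected in this assay from compound 2 to compound 4; the most likely outcome is another limit. Compound 4 is estimated at 15000 nM in this assay, between 7000 nM and 40000 nM. The expected step that the limit leaves unreadable from compound 2 to compound 4 is thus essentially none.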

Compound 4, half-maximal inhibitory concentration: 18000 nM
For compound 4 the middle estimate is 1.2-fold (0.08 log units) below the measured one; the measured number falls inside the stated range.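

The steps to compound 4 from compound 1, compound 2 and compound 3 cannot be read in size or direction, because only compound 4 has a measured number: the limit of > 10000 nM in this assay, at which 3 of the 4 values shown sit.

The compounds shown leave open how far compound 1, compound 2 and compound 3 actually lie from compound 4 in this assay, and whether any change on this oxygen moves the value at all.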